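Chloro in Place of Methoxycarbonyl: Expected Cytotoxicity of Compound 3

This account rests on a few compounds, and the source may have more. Where it says the series, first, only, none or still open, it means among the compounds named here.

Two compounds have been measured:
compound 1, `Cc1cc(NC(=O)Nc2ncccc2C)c2ccccc2n1`, > 25000 nM
compound 2, `COC(=O)c1ccc(NC(=O)Nc2cc(C)nc3ccccc23)cc1`, 17000 nM

In an ADME assay on Raji cells (Homo sapiens) for cytotoxicity, with a stated time of 72 h (on this read-out lower numbers stand for an effect already at smaller amounts and higher numbers for an effect only at larger amounts of compound), compound 1 reaches only a limit, > 25000 nM, which is not a number. This corresponds to the limit of > 25000 nM in this assay, at which 1 of the 2 values shown sits. In this assay, among the compounds with values here, compound 2 gives 17000 nM, the only actual number among the two values shown, so it is the sole anchor for any expectation.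

Compound 3, `Cc1cc(NC(=O)Nc2ccc(Cl)cc2)c2ccccc2n1`, has not yet been measured. It differs from compound 2 in one place: chloro in place of methoxycarbonyl on an aromatic carbon. Within the data shown here, no measured pair differs in a single place, so no measured step can guide the expectation. The change is expected to shift the number little in this assay, not beyond the usual scatter and in no clear direction. Compound 3 is therefore estimated at 20000 nM, with a range from 7000 nM to 50000 nM. The estimated step is a 1.2-fold higher number from compound 2 to compound 3 (0.07 log units; within the scatter).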

Compound 3, half-maximal effective concentration: > 25000 nM
Compound 3: only a limit was reported; the forecaster's own chance of this, stated with the estimate: 40%; middle value at least 1.2-fold (0.09 log units) from the limit.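

In this assay, within the data shown here, chloro in place of methoxycarbonyl on an aromatic carbon, para to a large group, gives the first readable step at this position: an at least 1.4-fold higher number from compound 2 to compound 3 (0.16 log units; that floor lies within the scatter). Since only the floor of that step can be read and it lies within the scatter, the result does not establish a real difference between the two groups, and the step between compound 1 and compound 3 cannot be read at all, as both values are limits. Compound 3 joins compound 1 at the top of the measured range, so only compound 2 still has an actual number: the limit of > 25000 nM in this assay, at which 2 of the 3 values shown sit.

The compounds shown leave open how far the true value of compound 3 lies from that of compound 2. They also leave open whether an amine or a carboxylic acid at this position would give a number clearly different from that of compound 2 in this assay.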